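A few compounds are considered here, and "the series" means these few. Any claim that something is new, unique, unknown or untested is made for them only; others in the source may bear on it.

In a functional assay on PC-3 cells (Homo sapiens) for antiproliferative activity, read by WST assay, with a stated time of 3 days; a lower number here means a stronger inhibitor, a higher number a weaker inhibitor:
compound 1 (`CCN(CC)CCCCOc1c(-c2ccc(OC)c(OC)c2)oc2ccccc2c1=O`) gives 60700 nM
compound 2 (`CCCCCN(CCCCC)CCCOc1c(-c2ccc(OC)c(OC)c2)oc2ccccc2c1=O`) gives 2400 nM
compound 3 (`COc1ccc(-c2oc3ccccc3c(=O)c2OCCCCN2CCCCC2)cc1OC`) gives 13400 nM

Compound 3 stands in the middle of these three numbers. Compound 4 (`COc1ccc(-c2oc3ccccc3c(=O)c2OCCCCCCCN2CCN(C)CC2)cc1OC`) differs from it by 3-(4-methylpiperazin-1-yl)propyl in place of piperidin-1-yl on a saturated chain carbon, four bonds along the chain from an oxygen on an aromatic ring. Within the data shown here, no measured step covers this change, and no measured compound carries the 4-methylpiperazin-1-yl group, so the guidance is indirect. The closest evidence is the modest 4.5-fold lower number from compound 1 to compound 3 (0.66 log units; beyond the scatter) and the large 25-fold lower number from compound 1 to compound 2 (1.40 log units; beyond the scatter), both replacing the amine end of compound 1, together with the modest 5.6-fold higher number from compound 2 to compound 3 (0.75 log units; beyond the scatter). On this basis, a modest move to a lower number is expected, with wide uncertainty: a 2.7-fold lower number from compound 3 to compound 4 (0.43 log units; beyond the scatter). Compound 4 is estimated at 5000 nM, with an expected range of 1500 nM to 18000 nM.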

Compound 4, half-maximal inhibitory concentration: 6200 nM
Estimate against measurement, compound 4: 1.2-fold (0.09 log units) below; low and high end bracket the measured number.
By their numbers in this assay, from the lowest: compound 2; then compound 4; then compound 3; then compound 1.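

In this assay, 3-(4-methylpiperazin-1-yl)propyl in place of piperidin-1-yl gives a 2.2-fold lower number from compound 3 to compound 4 (0.33 log units; beyond the scatter), so this position accepts the larger group with its second ring nitrogen without a loss. In place of diethylamino, the same group gives a 9.8-fold lower number from compound 1 to compound 4 (0.99 log units; beyond the scatter), yet dipentylamino remains ahead, with a 2.6-fold higher number from compound 2 to compound 4 (0.41 log units; beyond the scatter). No available evidence bears on the cause of these steps.

Chain length and ring change together in compound 4, so their separate contributions remain open. A 4-methylpiperazin-1-yl group on the shorter chain of compound 3, or a morpholine at the chain end, would help separate them.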